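An oxazole for a thiophene, judged on solubility

The source may hold more compounds than are shown below. What is called first, only, known or untested is meant among the compounds shown, and "the series" means these compounds.

Compound 3 `CC(C)(C)c1nc(-c2cccs2)c2c(N)c(C#N)c(N)nc2n1` carries a thiophen-2-yl group beside a tert-butyl group on its shared core, and in a physicochemical assay for solubility, in phosphate buffer, with a stated time of 18 h (on this read-out higher numbers stand for higher solubility and lower numbers for lower solubility), compound 3 gives 56000 nM. That is the lowest of the two numbers recorded, and the nearest neighbour, compound 2 `N#Cc1c(N)nc2nc(C3CCC3)ncc2c1N`, gives 217000 nM in this assay, a gap that lies beyond the scatter. Compound 1 `CC(C)c1ncc2c(N)c(C#N)c(N)nc2n1` reaches only a limit of this assay, > 1000000 nM, so it is a limit and not a number (the limit of > 1000000 nM in this assay, at which 1 of the 3 values shown sits).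

For the measured compounds named here, the one measured step is an at least 4.6-fold lower number from compound 1 to compound 2 (0.66 log units; beyond the scatter). Going by the values given here, it concerns a different place on the core from the thiophen-2-yl group and offers no direct precedent for compound 4 `CC(C)(C)c1nc(-c2ncco2)c2c(N)c(C#N)c(N)nc2n1`, which differs from compound 3 by 1,3-oxazol-2-yl in place of thiophen-2-yl on an aromatic carbon.

Among the compounds with values here, with no measured step touching that place, the expectation rests on compound 3 alone; a small step is expected, likely within the scatter, as compound 3 gives 56000 nM and the change is estimated at a 1.6-fold higher number from compound 3 to compound 4 (0.21 log units; within the scatter). Compound 4 is therefore expected to give about 90000 nM in this assay, with a range from 30000 nM to 300000 nM.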

Compound 4, solubility: 50000 nM
Compound 4: the middle estimate sits 1.8-fold (0.26 log units) above what was measured, within the range that was stated.
By their numbers in this assay, from the lowest: compounds 4 and 3 (each within the scatter of the next); then compound 2. At a limit, above all of these: compound 1.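

For the compounds shown here, this is the only measured step at this aromatic carbon, meta to a tert-butyl group, and in this assay the exchange of thiophen-2-yl for 1,3-oxazol-2-yl comes to a 1.1-fold lower number from compound 3 to compound 4 (0.05 log units; within the scatter), so the read-out does not separate the two compounds. A five-membered aromatic ring with 2 hetero atoms and 2 hydrogen-bond acceptors can therefore take the place of one with 1 hetero atom and 1 hydrogen-bond acceptor here without a difference beyond the scatter, at least for this one pair on the shared core. Nothing measured among the compounds shown bears on why these two groups give values so close together.

Only these two groups can be compared at this aromatic carbon, which leaves open whether an amine, a carboxylic acid or a phenyl ring there would give a number beyond the scatter of compound 3. As far as these compounds go, it also remains open whether the same exchange would give an equally small step on a core that carries isopropyl or cyclobutyl instead of tert-butyl.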